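Pyrrolidinyl to dimethylamino on the benzophenone-triazole series

A few compounds are considered here, and "the series" means these few. Any claim that something is new, unique, unknown or untested is made for them only; others in the source may bear on it.

Measured so far in a functional assay on the whole organism (strain CF-1) for positive allosteric modulation, with Mus musculus as the target; on this read-out higher numbers stand for an effect only at larger amounts of compound and lower numbers for an effect already at smaller amounts:
compound 1 `Cc1nnc(CN2CCCC2)n1-c1ccc(Cl)cc1C(=O)c1ccccc1Cl` gives 6 mg/kg
compound 2 `Cc1nnc(CN2CCCC2)n1-c1ccc(Cl)cc1C(=O)c1ccccc1` gives 1.8 mg/kg
compound 3 `CN(C)Cc1nnc(-c2ccco2)n1-c1ccc(Cl)cc1C(=O)c1ccccc1` gives 25 mg/kg

Compound 1 stands second highest of the three numbers in this assay. Its nearest neighbour is compound 2, reached by hydrogen in place of chloro on an aromatic carbon: a 3.3-fold lower number from compound 1 to compound 2 (0.52 log units; beyond the scatter). Among the compounds with values here, compound 3 lies furthest away with the highest number of the set, but it differs from compound 1 in more than one place, so no single step can be drawn from it.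

Compound 4 `Cc1nnc(CN(C)C)n1-c1ccc(Cl)cc1C(=O)c1ccccc1Cl` has not been measured. The change from compound 1 is dimethylamino in place of pyrrolidin-1-yl on a saturated chain carbon bound to an aromatic carbon. Within the data shown here, none of the measured steps touches this part of the molecule: the only step in hand, from compound 1 to compound 2, concerns a chloro substituent elsewhere. Compound 3 carries a dimethylamino group, yet its other differences from compound 1 prevent any reading of what that group alone contributes. Among the measured compounds shown here, with no step that bears on the change, the expectation for compound 4 is no step beyond the scatter: no change at the digits printed from compound 1 to compound 4 (within the scatter). Compound 4 is therefore estimated at 6 mg/kg in this assay, with a range from 2 mg/kg to 18 mg/kg.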

Compound 4, dose for half-maximal effect: 0.63 mg/kg
The estimate for compound 4 lay 9.5-fold (0.98 log units) above the measured number, and the stated range ends above it.
By their numbers in this assay, from the lowest: compound 4; then compound 2; then compound 1; then compound 3.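

The amine on the saturated chain carbon bound to an aromatic carbon is a place where the number in this assay responds: dimethylamino in place of pyrrolidin-1-yl gives a 9.5-fold lower number from compound 1 to compound 4 (0.98 log units; beyond the scatter). Within the data shown here, this is the first step read at this place, and in this single pair the group with no ring and 3 heavy atoms goes with the lower number, against 5 heavy atoms and a five-membered ring for pyrrolidin-1-yl. Nothing available accounts for the size of this step.

This one pair cannot separate the loss of the ring from the drop in heavy atoms, so an open-chain diethylamino group or a ring such as azetidin-1-yl or piperidin-1-yl remains to be placed against it. Also open, as far as these compounds go, is whether dimethylamino gives a similar step on the core of compound 2, which has hydrogen in place of chloro.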